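Benzofuran carbinols: amine-to-alcohol swap on the side chain

This account rests on a few compounds, and the source may have more. Where it says the series, first, only, none or still open, it means among the compounds named here.

Three compounds of the series have numbers in a functional assay on QG-56 cells (Homo sapiens) for antiproliferative activity; a lower number here means a stronger inhibitor, a higher number a weaker inhibitor. Compound 1 `COc1cccc(-c2cc(CN(C)C)cc3cc(C(O)(c4ccc(C#N)cc4)c4cncn4C)oc23)c1` gives 142 nM, the second highest of the three. Compound 3 `Cn1cncc1C(O)(c1ccc(Cl)cc1)c1cc2cc(C(=O)NN3CCOCC3)cc(-c3ccccc3)c2o1` gives 73.6 nM, which lies within the scatter of compound 1. Compound 2 `Cn1cncc1C(O)(c1ccc(C#N)cc1)c1cc2cc([N+](=O)[O-])cc(-c3ccccc3)c2o1` gives 1480 nM, well beyond the scatter from compound 1 and the highest number of the set. Among the measured compounds shown here, no pair of measured compounds differs in only one place, so no single-change step is available.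

Compound 4 `COc1cccc(-c2cc(CO)cc3cc(C(O)(c4ccc(C#N)cc4)c4cncn4C)oc23)c1` differs from compound 1 as follows: hydroxy in place of dimethylamino on a saturated chain carbon bound to an aromatic carbon. For the measured compounds named here, with no comparable step among the measured compounds, a modest weakening is expected, at the edge of the scatter. The step of a 1.8-fold higher number from compound 1 to compound 4 (0.26 log units; within the scatter) is the expected size. Compound 4 is estimated at 260 nM, within 80 nM to 850 nM.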

Compound 4, half-maximal inhibitory concentration: 16.8 nM
The estimate for compound 4 lay 15-fold (1.19 log units) above the measured number; the whole stated range lies above it.
By their numbers in this assay, from the lowest: compound 4; then compounds 3 and 1 (each within the scatter of the next); then compound 2.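

In this assay, hydroxy in place of dimethylamino on a saturated chain carbon bound to an aromatic carbon gives an 8.5-fold lower number from compound 1 to compound 4 (0.93 log units; beyond the scatter). The number at this position therefore responds to the group carried there, and the dimethylamino group is not needed to reach the nanomolar range. No measurement at hand accounts for the shift.

On these data alone, whether the drop follows from the hydroxy itself or from the loss of dimethylamino stays open; a methoxy, a primary amine or a carboxylic acid at this place would separate the two. The change is read in one pair only, on the core of compound 1.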